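Large steps on one ring carbon: compound 3 to compound 4

A few compounds are considered here, and "the series" means these few. Any claim that something is new, unique, unknown or untested is made for them only; others in the source may bear on it.

Measured in a functional assay for inhibition, with Sus scrofa as the target; on this read-out lower numbers stand for stronger inhibition and higher numbers for weaker inhibition:
- compound 1 `CC1(C)Oc2ccc(C#N)cc2[C@@H](n2ccccc2=O)[C@]1(C)O`: > 100000 nM, a limit
- compound 2 `CC1(C)Oc2ccc(C#N)cc2[C@@H](Nn2ccccc2=O)[C@]1(C)O`: > 100000 nM, a limit
- compound 3 `CC1(C)Oc2ccc(C#N)cc2[C@@H](Oc2ccnc(O)c2)[C@]1(C)O`: 4 nM

Among the measured compounds shown here, compound 3 is the only compound here with a number rather than a limit, and it is the strongest of the three. The next compound is compound 4 `CC1(C)Oc2ccc(C#N)cc2[C@@H](n2nc(N)ccc2=O)[C@]1(C)O`, and the change is a group of 8 heavy atoms (4 carbon, 3 nitrogen, 1 oxygen; one six-membered aromatic ring with 2 hetero atoms) in place of a group of 8 heavy atoms (5 carbon, 1 nitrogen, 2 oxygen; one six-membered aromatic ring with 1 hetero atom), on a saturated ring carbon. For the measured compounds named here, two measured steps bear on it: an at least 25000-fold lower number from compound 1 to compound 3 (4.39 log units; beyond the scatter) and an at least 25000-fold lower number from compound 2 to compound 3 (4.39 log units; beyond the scatter). Both are large, so swaps of the group on this saturated ring carbon can move the read-out widely, and a large loss is the likelier outcome in this assay. The expected change is a 2500-fold higher number from compound 3 to compound 4 (3.40 log units; beyond the scatter), towards weaker inhibition. The estimate for compound 4 is 10000 nM, with an expected range of 200 nM to 100000 nM.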

Compound 4, half-maximal inhibitory concentration: 40000 nM
Beside the measured number, compound 4's estimate is 4.0-fold (0.60 log units) below it; measured number inside the range.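

In this assay, among the compounds shown here, the change reads as a 10000-fold higher number from compound 3 to compound 4 (4.00 log units; beyond the scatter), the first step on this saturated ring carbon with a number at both ends. The group in compound 4 also separates from the other two groups, with an at least 2.5-fold lower number from compound 2 to compound 4 (0.39 log units; beyond the scatter) and an at least 2.5-fold lower number from compound 1 to compound 4 (0.39 log units; beyond the scatter). Those two steps are bounds rather than sizes, as compound 1 and compound 2 stand at a limit: the limit of > 100000 nM in this assay, at which 2 of the 4 values shown sit.

The ring and its link to the carbon change together from compound 3 to compound 4, so neither can be read alone. From the compounds shown here alone, how an open-chain amine or a methoxy-bearing ring would read on this carbon stays open.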